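Metabolic stability notes on a peptidic amide series

The source may hold more compounds than are shown below. What is called first, only, known or untested is meant among the compounds shown, and "the series" means these compounds.

Measured so far:
Compound 1 `COC(=O)C12CC1CCN(C(=O)[C@H](CC(C)C)NC(=O)[C@H](CO)NC(=O)[C@@H](NC(=O)OCc1ccccc1)C(C)C)C2` — in an ADME assay for metabolic stability (on this read-out higher numbers stand for a longer-lived compound and lower numbers for a shorter-lived compound), compound 1 gives > 6 h, which is a limit of the assay.
Compound 2 `COC(=O)C12CC1CCN(C(=O)[C@H](CC(C)C)NC(=O)[C@H](CO)NC(=O)[C@@H](NC(=O)c1cccc(O)c1C)C(C)C)C2` — in this assay compound 2 gives > 6 h, which is again a limit of the assay.

Compound 2 therefore stands at the upper limit of the read-out, with no number beneath it. For the measured compounds named here, the only step measured between neighbours, a step that the two limits leave unreadable from compound 1 to compound 2, cannot be sized, since both ends are limits; the record so far is summed up by the limit of > 6 h in this assay, at which 2 of the 2 values shown sit.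

The next compound, compound 3 `COC(=O)C12CC1CCN(C(=O)[C@H](CC(C)C)NC(=O)[C@H](CO)NC(=O)[C@@H](NC(=O)C1=CCCNC1)C(C)C)C2`, is not yet measured. It differs from compound 2 by a group of 6 heavy atoms (5 carbon, 1 nitrogen; one six-membered non-aromatic ring with 1 hetero atom) in place of a group of 8 heavy atoms (7 carbon, 1 oxygen; one six-membered aromatic ring of carbon only), on a carbonyl carbon.

Going by the values given here, no measured step bears on this exchange in a readable way, so no direction can be derived from the series. With both neighbours long-lived, compound 3 is expected to remain long-lived as well, the step of an at least 1.2-fold lower number from compound 2 to compound 3 (0.07 log units; that floor lies within the scatter) being expected to stay within the scatter. Compound 3 is estimated at 5 h, with a range from 1.5 h to 6 h, and a fair chance that only the limit is reported again.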

Compound 3, half-life: > 6 h
Compound 3: only a limit was reported; the forecaster's own chance of this, stated with the estimate: 50%; at least 1.2-fold (0.07 log units) between middle value and limit.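

In this assay compound 3 gives > 6 h, again a limit of the assay. For the compounds shown here, no step among compound 1, compound 2 and compound 3 can be read. The compounds shown leave open how far their half-lives differ and whether any exchange on this carbonyl carbon would bring a value within the read-out; the record stands at: the limit of > 6 h in this assay, at which 3 of the 3 values shown sit.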